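This account rests on a few compounds, and the source may have more. Where it says the series, first, only, none or still open, it means among the compounds named here.

Compound 1 `Cn1cccc1C(=O)/C=C/c1ccc2c(c1)B(O)OC2` carries a 1-methyl-1H-pyrrol-2-yl group on the carbonyl carbon of the shared core. In a toxicity assay on WI-38 cells (Homo sapiens) for cytotoxicity, read by MTT assay, with a stated time of 48 h (a lower number here means a stronger inhibitor, a higher number a weaker inhibitor), compound 1 gives > 100000 nM; this is a limit of the assay, not a number, so compound 1 stands only at the limit of > 100000 nM in this assay, at which 1 of the 3 values shown sits. Two other members of the series carry a six-membered aromatic ring of carbon only on the carbonyl carbon and have numbers: compound 2 `O=C(/C=C/c1ccc2c(c1)B(O)OC2)c1ccc(Cl)c(Cl)c1` gives 12500 nM in this assay, and compound 3 `Cc1ccc(C(=O)/C=C/c2ccc3c(c2)B(O)OC3)cc1C` gives 22000 nM. Those two values lie within the scatter of each other.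

Compound 4 `O=C(/C=C/c1ccc2c(c1)B(O)OC2)c1ccccc1O` is not yet measured and differs from compound 1 in one place (2-hydroxyphenyl in place of 1-methyl-1H-pyrrol-2-yl on a carbonyl carbon). For the measured compounds named here, no measured step joins such a pair, so the size of the step is open. Compound 4, like compound 2 at 12500 nM and compound 3 at 22000 nM, carries a six-membered aromatic ring of carbon only on the carbonyl carbon. For compound 4 the expected step is an at least 3.3-fold lower number from compound 1 to compound 4 (0.52 log units; beyond the scatter), toward stronger inhibition in this assay, though a limit again is possible. Compound 4 is estimated at 30000 nM, with a range from 10000 nM to 100000 nM.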

Compound 4, half-maximal inhibitory concentration: > 100000 nM
Compound 4 ended at the assay's limit (the forecaster's own chance of this, stated with the estimate: 30%); middle value at least 3.3-fold (0.52 log units) from the limit.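

Compound 1 and compound 4 both stand at a limit of this assay, not at a number, so no step between them can be read: the limit of > 100000 nM in this assay, at which 2 of the 4 values shown sit.

The compounds shown leave open whether 2-hydroxyphenyl and 1-methyl-1H-pyrrol-2-yl on a carbonyl carbon differ at all in this assay.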